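The compounds below may be only part of what the source reports. "The series", "measured", "known", "first", "only" and "open" are said of these compounds alone.

Working notes on the series. Two compounds carry numbers in an assay on isolated protein for inhibition of histone deacetylase 8 (Homo sapiens), read by fluorescence, tested at 1 uM; on this read-out higher numbers stand for more inhibition at the one concentration tested (going by the name of the read-out) and lower numbers for less inhibition. Compound 1, `CC(C)(C(=O)Nc1ccc(C(=O)Nc2ccc(F)cc2N)cc1)c1ccccc1`, gives 0% in this assay, the lowest of the two values. Going by the values given here, compound 2, `CC(C)[C@@H](C(=O)Nc1ccc(C(=O)Nc2ccccc2N)cc1)c1ccccc1`, gives 38% in this assay, a number that stands above that of compound 1 by a margin beyond the scatter; no single-point step connects compound 2 to compound 1, so only the two values themselves are on record.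

Compound 3, `CC(C)(C(=O)Nc1ccc(C(=O)Nc2ccccc2N)cc1)c1ccccc1`, is not yet measured. It differs from compound 1 in one place: hydrogen in place of fluoro on an aromatic carbon. The fluoro leaves and a hydrogen enters at the aromatic carbon meta to the amino group and para to the large group, turning the 2-amino-4-fluorophenyl into a 2-aminophenyl.

Nothing in the measured pair isolates this change, so its size is open. Compound 3 shares the unsubstituted 2-aminophenyl with compound 2, which differs elsewhere, so the value of compound 2, 38%, is only a loose pointer. A modest rise from compound 1 is expected, with a number 15 percentage points higher from compound 1 to compound 3 (beyond the scatter) as the estimated step. Compound 3 is expected to give about 15% in this assay, within 0% to 40%.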

Compound 3, a percentage reported as inhibition, at one concentration (the size of the read-out at that concentration, not a potency): 0%
Estimate against measurement, compound 3: 15 percentage points above, and the stated range covers the measured number.
By their numbers in this assay, from the lowest: compounds 1 and 3 (each within the scatter of the next); then compound 2.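

In this assay, hydrogen in place of fluoro on the aromatic carbon meta to the amino group and para to the large group, turning the 2-amino-4-fluorophenyl into a 2-aminophenyl, gives no change at the digits printed from compound 1 to compound 3 (within the scatter). On this core, the fluoro therefore does not account for the reading of compound 1 at 0%, as compound 3, with the plain 2-aminophenyl, reads 0%. Nothing available explains this result at this position.

Going by these compounds, both numbers lie at the bottom of the read-out at the one concentration tested, so any contribution of the fluoro too small to lift the number in this core would not show, and whether the same exchange matters on a compound with a clear reading, such as compound 2 at 38% in this assay, stays open. Also open, on these data alone, is how a chloro, a methoxy or a dimethylamino group at this aromatic carbon would read on the core of compound 3.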